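Benzyl for methyl on the aryl ether of a thiosemicarbazone

The compounds below may be only part of what the source reports. "The series", "measured", "known", "first", "only" and "open" are said of these compounds alone.

Compound 1 `Cn1cc(/C=N/NC(N)=S)c2ccccc21` — > 200000 nM
Compound 2 `NC(=S)N/N=C/c1ccc(F)c2ccccc12` — 39000 nM
Compound 3 `COc1ccc(/C=N/NC(N)=S)c2ccccc12` — 47000 nM

In a toxicity assay on THP-1 cells (Homo sapiens) for cytotoxicity, read by MTT assay, with a stated time of 72 h (a lower number here means that less compound is needed, a higher number that more compound is needed for the effect), compound 1 gives only a limit, (the limit of > 200000 nM in this assay, at which 1 of the 3 values shown sits). Compound 2 and compound 3 sit within the scatter of each other, so neither can be set apart. For the measured compounds named here, the one measured step, a 1.2-fold higher number from compound 2 to compound 3 (0.08 log units; within the scatter), stays within the scatter. Compound 4 `NC(=S)N/N=C/c1ccc(OCc2ccccc2)c2ccccc12` differs from compound 3 by phenyl in place of hydrogen on a saturated chain carbon bound to an oxygen on an aromatic ring. Going by the values given here, no measured step tests a change of this kind, and the fluoro-to-methoxy step gives no sign that the aryl ether end moves the number. Compound 3 to compound 4 is therefore expected to show a 1.2-fold lower number from compound 3 to compound 4 (0.07 log units; within the scatter), a step not beyond the scatter. Compound 4 is estimated at 40000 nM, within 15000 nM to 150000 nM.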

Compound 4, half-maximal effective concentration: 27000 nM
Compound 4: middle estimate off by 1.5-fold (0.17 log units), on the high side; the range from low to high includes it.
By their numbers in this assay, from the lowest: compounds 4, 2 and 3 (each within the scatter of the next). At a limit, above all of these: compound 1.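

In this assay the phenyl on the saturated chain carbon bound to an oxygen on an aromatic ring gives a 1.7-fold lower number from compound 3 to compound 4 (0.24 log units; within the scatter) and thus shows that methoxy to benzyloxy, a far larger change than any tested before, leaves the number within the scatter. The comparison with the fluoro compound agrees, with a 1.4-fold lower number from compound 2 to compound 4 (0.16 log units; within the scatter) on the same footing. Nothing measured here gives a reason for either step.

Going by these compounds, whether an amine or a carboxylic acid in place of that phenyl would also leave the number within the scatter stays open.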